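The source may hold more compounds than are shown below. What is called first, only, known or untested is meant among the compounds shown, and "the series" means these compounds.

Compound 1 `O=C(Nc1ccc(C(F)(F)F)cc1)c1cc(Cl)c(-c2ccccc2)cc1O`: 770 nM
Compound 2 `N#Cc1ccc(NC(=O)c2ccc(-c3ccccc3)cc2O)cc1`: 410 nM

Both values come from a functional assay on KG-1 cells (Homo sapiens) for cytotoxicity, read by luminescence and CellTiter-Glo, with a stated time of 3 days; on this read-out lower numbers stand for stronger inhibition and higher numbers for weaker inhibition. Among the measured compounds shown here, compound 2, at 410 nM, lies within the scatter of compound 1, the only other compound measured, so the two cannot be told apart. Compound 3 `N#Cc1ccc(NC(=O)c2cc(Cl)c(-c3ccccc3)cc2O)cc1` has not yet been measured. It differs from compound 2 by a single change, chloro in place of hydrogen on an aromatic carbon, ortho to a phenyl group and para to a hydroxy group.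

For the measured compounds named here, no measured pair isolates this change, so the evidence for its effect is thin. Compound 1 also carries a chloro group and gives 770 nM, so no step beyond the scatter is expected in this assay. The estimate amounts to an expected 1.1-fold higher number from compound 2 to compound 3 (0.04 log units; within the scatter). For compound 3 the expected value is 450 nM, with an estimated range of 150 nM to 1300 nM.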

Compound 3, half-maximal inhibitory concentration: 480 nM
Compound 3: the middle estimate sits 1.1-fold (0.03 log units) below what was measured, within the range that was stated.
By their numbers in this assay, from the lowest: compounds 2, 3 and 1 (each within the scatter of the next).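

In this assay, chloro in place of hydrogen on an aromatic carbon, ortho to a phenyl group and para to a hydroxy group, now has a pair that isolates it: a 1.2-fold higher number from compound 2 to compound 3 (0.07 log units; within the scatter) is a step within the scatter, so compound 3 cannot be told apart from compound 2. With the chloro group present in both compounds, the second pair gives a 1.6-fold lower number from compound 1 to compound 3 (0.21 log units; within the scatter), also within the scatter, so cyano in place of trifluoromethyl on an aromatic carbon cannot be resolved here either. No measurement at hand offers an explanation for how close these numbers lie.

The compounds shown leave open whether bromo, a methoxy group or an amine on this same carbon would give a step beyond the scatter. They also leave open what a carboxylic acid in place of the cyano group would do.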